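The source may hold more compounds than are shown below. What is called first, only, known or untested is meant among the compounds shown, and "the series" means these compounds.

Two compounds of the series carry numbers in a functional assay on the whole organism for inhibition, with Rattus norvegicus as the target, read by paw edema, with stated times of 30 min and 3 h, at a dose of 50 mg/kg by the intraperitoneal route; on this read-out lower numbers stand for less inhibition and higher numbers for more inhibition at the one dose given (going by the name of the read-out). Compound 1 `O=C(O)c1c(O)c(F)c(F)c(F)c1F` gives 64% in this assay, and this is the only single number shown for it, with one further entry that carries no number. Compound 2 `O=C(O)c1cc(F)c(F)c(F)c1O` gives 46.7%; no result reported (2 entries) in this assay; its several entries read (the several entries of compound 2 in this assay, 46.7%; no result reported (2 entries)). Within the data shown here, no pair of measured compounds differing in one place is available, so no measured step can be drawn on here, and the two values of compound 1 and compound 2 are taken only as what they show.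

Compound 3 `CC(=O)Oc1c(F)c(F)c(F)c(F)c1C(=O)O` is not yet measured in this assay. It differs from compound 1 by acetyl in place of hydrogen on an oxygen on an aromatic ring. The expected step of a number 6 percentage points lower from compound 1 to compound 3 (within the scatter) is judged to stay within the usual scatter, with no direction beyond it. Compound 3 is estimated to give 58% in this assay, with a range from 35% to 80%.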

Compound 3, a percentage reported as inhibition, in the whole organism at one dose (the size of the read-out at that dose, not a potency): 65.6%
Compound 3: the middle estimate sits 7.6 percentage points below what was measured; low and high end bracket the measured number.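

In this assay the series now has its first measured step, a number 1.6 percentage points higher from compound 1 to compound 3 (within the scatter) for acetyl in place of hydrogen on an oxygen on an aromatic ring. On this single pair, a free hydroxy at this position is therefore not needed for the read-out at the one dose given, and hydroxy to acetoxy leaves no change that can be told from the scatter. No measurement shown here bears on why this step reads as it does.

On these data alone, it remains open whether a longer acyl chain such as butanoyl, or a methoxy or an amine in place of the hydroxy, would read the same on the core of compound 1. As far as these compounds go, it is also open whether acetyl on the hydroxy of compound 2 would give a step like this one.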